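A few compounds are considered here, and "the series" means these few. Any claim that something is new, unique, unknown or untested is made for them only; others in the source may bear on it.

Measured compounds:
- compound 1 `CC(C)S(=O)(=O)OC1CCC(CN2CCN(c3cc(=O)c4cc(C(F)(F)F)cc([N+](=O)[O-])c4s3)CC2)CC1` — > 64 ug/mL
- compound 2 `O=C(OC1CCC(CN2CCN(c3cc(=O)c4cc(C(F)(F)F)cc([N+](=O)[O-])c4s3)CC2)CC1)c1cccc(F)c1` — > 64 ug/mL

In an ADME assay on Vero cells (Chlorocebus sabaeus) for cytotoxicity, read by MTT assay, with a stated time of 48 h (a lower number here means a stronger inhibitor, a higher number a weaker inhibitor), compound 1 gives > 64 ug/mL, which is a limit of the assay rather than a number. Compound 2 gives > 64 ug/mL in this assay, again only a limit. The step that the two limits leave unreadable from compound 1 to compound 2 therefore cannot be read. Compound 2 stands at the limit of > 64 ug/mL in this assay, at which 2 of the 2 values shown sit, with no measured number of its own.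

Compound 3 `COc1ccc(C(=O)OC2CCC(CN3CCN(c4cc(=O)c5cc(C(F)(F)F)cc([N+](=O)[O-])c5s4)CC3)CC2)cc1` differs from compound 2 as follows: 4-methoxyphenyl in place of 3-fluorophenyl on a carbonyl carbon. Going by the values given here, the only measured step bearing on this assay is the one from compound 1 to compound 2, and its size is not readable, so it gives no direction for this change. Compound 3 is therefore expected to sit at the same limit, with no step beyond the scatter, estimated as a step that the limit leaves unreadable from compound 2 to compound 3. The estimate for compound 3 in this assay is 80 ug/mL, within 45 ug/mL to 150 ug/mL.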

Compound 3, half-maximal inhibitory concentration: > 64 ug/mL
Compound 3: only a limit was reported (the forecaster's own chance of this, stated with the estimate: 80%); the middle value does not contradict the limit.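

Compound 3 gives only a limit in this assay, as do compound 1 and compound 2, so no step among the three can be read: the limit of > 64 ug/mL in this assay, at which 3 of the 3 values shown sit.

The compounds shown leave open what actual values these three have in this assay, and whether exchanging the groups on the oxygen changes them at all.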